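A Methyl Added to a Second Scaffold

A few compounds are considered here, and "the series" means these few. Any claim that something is new, unique, unknown or untested is made for them only; others in the source may bear on it.

Two pairs of compounds share a single change. Compound 1 `Cc1cccc(C[C@H]2C(=O)OC[C@@H]2Cc2ccccc2)c1` and compound 2 `Cc1ccc(C[C@H]2C(=O)OC[C@@H]2Cc2ccccc2)cc1C` form the first pair; compound 3 `Cc1ccc(C[C@H]2COC[C@@H]2Cc2ccc(Cl)c(Cl)c2)cc1` and the unmeasured compound 4 `Cc1ccc(C[C@H]2COC[C@@H]2Cc2ccc(Cl)c(Cl)c2)cc1C` form the second. The difference between the two cores is not broken down here.

In a functional assay on HL-60 cells (Homo sapiens) for cytotoxicity, read by WST assay, with a stated time of 48 h (on this read-out lower numbers stand for an effect already at smaller amounts and higher numbers for an effect only at larger amounts of compound), compound 1 gives 53000 nM, and compound 2 gives 35000 nM. The step of a 1.5-fold lower number from compound 1 to compound 2 (0.18 log units; within the scatter) went with this change: methyl in place of hydrogen on an aromatic carbon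

Compound 3 gives 21000 nM in this assay, a value that sits close to that of compound 2 and noticeably lower than that of compound 1.

Compound 4 carries the same kind of change on its own core: methyl in place of hydrogen on an aromatic carbon The surroundings are not identical, since in compound 2 the entering methyl is para to a large group, while in compound 4 it is meta to a large group.

Because the step of a 1.5-fold lower number from compound 1 to compound 2 (0.18 log units; within the scatter) was small, a similar small step is expected here, a 1.4-fold lower number from compound 3 to compound 4 (0.15 log units; within the scatter). Compound 4 is therefore estimated at 15000 nM in this assay, with a likely range from 7000 nM to 30000 nM.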

Compound 4, half-maximal effective concentration: 36000 nM
The estimate for compound 4 lay 2.4-fold (0.38 log units) below the measured number; measured number above the stated range.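

In this assay, methyl in place of hydrogen on an aromatic carbon went with a 1.7-fold higher number from compound 3 to compound 4 (0.23 log units; within the scatter), so on this second core the step is again too small to count as a real change. Set side by side, the two steps cannot be told apart: the same change on two cores in this assay, a 1.5-fold lower number (0.18 log units; within the scatter) from compound 1 to compound 2 and a 1.7-fold higher number (0.23 log units; within the scatter) from compound 3 to compound 4, 2.6-fold (0.41 log units) apart, within the scatter of two such steps. This fits the idea that adding this methyl makes little measurable difference on either core, but it does not show that the two cores respond in the same way, and two small steps make no general rule for other cores or other places on the ring.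

The compounds shown leave open whether a different group in this place, such as a hydroxyl group, an amine or a carboxylic acid, would give a step beyond the scatter. On these data alone, the share of the core itself in these numbers also stays open: each pair compared here keeps its core fixed.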